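Swapping Fluoro for Methoxy at the Assay Limit

The source may report more compounds than this note shows. Statements on the series, on what has been measured and on what is new or still open speak of the compounds shown alone.

Compounds measured in an ADME assay on HS27 cells (Homo sapiens) for antiproliferative activity, read by sulforhodamine B assay, with a stated time of 48 h; on this read-out higher numbers stand for weaker inhibition and lower numbers for stronger inhibition:
- compound 1 `O=C(O)c1cc2cc(-c3ccc(F)cc3)ccc2n1O`: > 100000 nM (a limit)
- compound 2 `O=C(O)c1cc2ccc(-c3ccc(F)cc3)cc2n1O`: > 100000 nM (a limit)

Compound 2 stands at > 100000 nM, which is a limit of the assay and not a number. For the measured compounds named here, the same is true of compound 1, so neither compound has an exact value, and no step between them can be read from the data.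

The next compound, compound 3 `COc1ccc(-c2ccc3cc(C(=O)O)n(O)c3c2)cc1`, is made from compound 2 by one change: methoxy in place of fluoro on an aromatic carbon, para to a large group (methoxy in place of fluoro on an aromatic carbon).

Going by the values given here, the only guide in this assay is the limit of > 100000 nM in this assay, at which 2 of the 2 values shown sit. On that basis, no step beyond the usual scatter is expected, in either direction, and the assay may well report only a limit again. The estimated a number no higher from compound 2 to compound 3 (the limit leaves the size open) is therefore small. For compound 3 the expected value is 100000 nM, with an estimated range from 40000 nM to 200000 nM.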

Compound 3, half-maximal inhibitory concentration: > 100000 nM
Compound 3 was reported as a limit (the forecaster's own chance of this, stated with the estimate: 85%); the middle value sits exactly at the limit.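

In this assay compound 3 gives > 100000 nM, a limit of the assay and not a number. Compound 2 also stands at a limit, so no step can be read from compound 2 to compound 3. What the compounds shown leave open is whether methoxy in place of fluoro changes the activity at all, as all that can be seen is: the limit of > 100000 nM in this assay, at which 3 of the 3 values shown sit.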